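The compounds below may be only part of what the source reports. "The series", "measured", "known", "first", "only" and "open" are said of these compounds alone.

Working notes on the series. Three compounds carry measurements in a functional assay on the whole organism for inhibition, with Brassica napus as the target, with a stated time of 72 h, tested at 10 mg/L; a higher number here means more inhibition of growth at the concentration tested, a lower number less inhibition of growth. Compound 1 `COc1cc(Cl)nc2n/c(=N/C(=O)c3c(-c4ccc(Cl)cc4Cl)noc3C)sn12` gives 28.6% there. Compound 3 `COc1cc(OC)n2s/c(=N\C(=O)c3c(-c4ccc(Cl)cc4Cl)noc3C)nc2n1` gives 49.3% in this assay. Compound 2 `COc1cc(C)nc(NC(=S)NC(=O)c2c(-c3ccc(Cl)cc3Cl)noc2C)n1` gives 15.7% in this assay, the lowest of the three numbers; its nearest neighbour by value is compound 1 and its furthest is compound 3, both gaps beyond the scatter. For the measured compounds named here, the only single-point step within the measured set is a number 20.7 percentage points higher from compound 1 to compound 3 (beyond the scatter), a methoxy in place of chloro on a core that is not the core of compound 2.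

Compound 4 `Cc1cc(O)nc(NC(=S)NC(=O)c2c(-c3ccc(Cl)cc3Cl)noc2C)n1` is not yet measured in this assay. Its difference from compound 2 is hydrogen in place of methyl on an oxygen on an aromatic ring so that 4-methoxy-6-methylpyrimidin-2-yl becomes 4-hydroxy-6-methylpyrimidin-2-yl. Going by the values given here, no measured pair shows this change; the one measured step, a number 20.7 percentage points higher from compound 1 to compound 3 (beyond the scatter), concerns another group on another core and does not bear on it. With nothing to point in either direction, the expected step is none beyond the scatter, which the estimate renders as a number 0.3 percentage points higher from compound 2 to compound 4 (within the scatter). Compound 4 is therefore expected to give about 16% in this assay, with a range from 4% to 30%.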

Compound 4, percent growth inhibition at one concentration: 6.7%
Estimate against measurement, compound 4: 9.3 percentage points above; the measured number falls inside the stated range.
By their numbers in this assay, from the lowest: compounds 4 and 2 (each within the scatter of the next); then compound 1; then compound 3.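

In this assay, this position now has its first direct reading: hydrogen in place of methyl on the oxygen, which turns methoxy into hydroxy, gives a number 9 percentage points lower from compound 2 to compound 4 (within the scatter) and so no change that can be told from the scatter. Compound 2 and compound 4 therefore count as one level in this read-out, and removing this methyl from the 4-methoxy-6-methylpyrimidin-2-yl group is not shown to alter growth inhibition at the concentration tested. Nothing available bears on the reason for the size of this step.

For the compounds shown here, still open is whether this position stays as flat with a different group on the same aromatic carbon, such as an amine or a longer chain like ethoxy, since methoxy and hydroxy are the only two groups read here. Going by these compounds alone, also open is whether hydroxy on the core of compound 1 would behave as it does here, given that the one step on that core, methoxy in place of chloro, reads as a number 20.7 percentage points higher from compound 1 to compound 3 (beyond the scatter) and says nothing about a free hydroxy group in this assay on either core.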